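Substituents on the ring amine nitrogen: next step

A few compounds are considered here, and "the series" means these few. Any claim that something is new, unique, unknown or untested is made for them only; others in the source may bear on it.

Of the compounds shown here, three measured so far share one core. Compound 1 `CN1CCN(c2ccc(C3=NNC(c4ccc(N(C)C)cc4)C3)cc2)CC1` carries hydrogen on the amine nitrogen in a ring; in a functional assay on NCI-H1975 cells (Homo sapiens) for inhibition, read by sulforhodamine B assay, tested at 10 uM (a higher number here means more inhibition at the concentration tested (going by the name of the read-out), a lower number less inhibition), compound 1 gives 2.4%. Compound 2 `CC(=O)N1N=C(c2ccc(N3CCN(C)CC3)cc2)CC1c1ccc(N(C)C)cc1` carries acetyl at that nitrogen, and in this assay compound 2 gives -1.9%. Compound 3 `COC(=O)CC(=O)N1N=C(c2ccc(N3CCN(C)CC3)cc2)CC1c1ccc(N(C)C)cc1` carries ((methoxycarbonyl)methyl)carbonyl there, and in this assay compound 3 gives -2.2%. Compound 2 stands among three numbers that do not separate from one another: a number 4.3 percentage points lower from compound 1 to compound 2 (within the scatter), a number 0.3 percentage points lower from compound 2 to compound 3 (within the scatter), and also a number 4.6 percentage points lower from compound 1 to compound 3 (within the scatter).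

Compound 4 `CN1CCN(c2ccc(C3=NN(S(C)(=O)=O)C(c4ccc(N(C)C)cc4)C3)cc2)CC1` is not yet measured. The change is methylsulfonyl in place of acetyl on an amine nitrogen in a ring, on the five-membered non-aromatic ring with 2 nitrogen. Among the compounds with values here, the steps that bear on it are the two earlier substitutions at the same nitrogen, both within the scatter, and the chain extension within the acetyl, also within the scatter. No step beyond the scatter is therefore expected in this assay, in either direction. Compound 4 is expected to give -1%, with a range from -12% to 10%. The estimated step is a number 0.9 percentage points higher from compound 2 to compound 4 (within the scatter).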

Compound 4, a percentage reported as inhibition, at one concentration (the size of the read-out at that concentration, not a potency): -1.3%
Compound 4: middle estimate off by 0.3 percentage points, on the high side, within the range that was stated.
By their numbers in this assay, from the lowest: compounds 3, 2, 4 and 1 (each within the scatter of the next).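

In this assay, methylsulfonyl at the amine nitrogen in a ring does not separate from either carbonyl-linked group (a number 0.6 percentage points higher from compound 2 to compound 4 (within the scatter); a number 0.9 percentage points higher from compound 3 to compound 4 (within the scatter)), so the flat reading at this position now extends from acetyl and ((methoxycarbonyl)methyl)carbonyl to a sulfur-linked group. Nor does it separate from hydrogen at that nitrogen (a number 3.7 percentage points lower from compound 1 to compound 4 (within the scatter)), which leaves all three substituents shown indistinguishable from compound 1. No measurement at hand accounts for this flat reading.

As far as these compounds go, all four values lie close to zero at the single concentration tested, so it remains open whether any group at this nitrogen gives a readable inhibition of these cells. Also open, from the compounds shown here alone, is how an aminoacetyl group, a carboxylic acid at the end of the acetyl chain or a benzoyl group would read here.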